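Compound 1 gains an ethynyl group: what to expect

A few compounds are considered here, and "the series" means these few. Any claim that something is new, unique, unknown or untested is made for them only; others in the source may bear on it.

Within the data shown here, in a functional assay on HCT-116 cells (Homo sapiens) for antiproliferative activity, read by MTT assay, with a stated time of 72 h (on this read-out lower numbers stand for stronger inhibition and higher numbers for weaker inhibition), compound 1 `O=C(CCc1cccc2c1B(O)OC2)Nc1ccccc1` gives 350 nM as the lower of the two actual numbers so far. Compound 2 `CC(C)(C)OC(=O)Nc1ccc(NC(=O)CCc2cccc3c2B(O)OC3)cc1` gives 24000 nM as the other. Compound 3 `CCOC(=O)c1ccc(NC(=O)CCc2cccc3c2B(O)OC3)cc1` reads > 100000 nM and this is a limit, not a number. Compound 4 `C#Cc1ccccc1NC(=O)CCc1cccc2c1B(O)OC2` differs from compound 1 by ethynyl in place of hydrogen on an aromatic carbon with ethynyl in place of hydrogen on an aromatic carbon, ortho to a large group. The closest guides are the two other additions to compound 1, which gave a 69-fold higher number from compound 1 to compound 2 (1.84 log units; beyond the scatter) and an at least 280-fold higher number from compound 1 to compound 3 (2.45 log units; beyond the scatter) as large steps upward. Ethynyl is the smaller entering group, so a milder rise is expected, an estimated 4.3-fold higher number from compound 1 to compound 4 (0.63 log units; beyond the scatter) overall. In this assay the expected value for compound 4 is 1500 nM within a range from 300 nM to 12000 nM as the estimate.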

Compound 4, half-maximal inhibitory concentration: 1400 nM
For compound 4 the middle estimate is 1.1-fold (0.03 log units) above the measured one; low and high end bracket the measured number.
By their numbers in this assay, from the lowest: compound 1; then compound 4; then compound 2. At a limit, above all of these: compound 3.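

In this assay, the aromatic carbon ortho to a large group takes ethynyl at a moderate cost: a 4.0-fold higher number from compound 1 to compound 4 (0.60 log units; beyond the scatter). This is smaller than a 69-fold higher number from compound 1 to compound 2 (1.84 log units; beyond the scatter), so not every addition to compound 1 costs as much, although compound 2 and compound 4 differ in more than one place, so the group and its position cannot be separated. Nothing measured here explains the step from hydrogen to ethynyl.

Still open, going by these compounds, is how an amine or a carboxylic acid on this same carbon would compare with ethynyl.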